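Methyl in Place of Iodo on the Phenyl Urea

The compounds below may be only part of what the source reports. "The series", "measured", "known", "first", "only" and "open" are said of these compounds alone.

Compound 1, `O=C(Nc1ccc([N+](=O)[O-])cc1)N[C@H]1CC[C@H](Oc2ccc(F)cc2)CC1`: 2300 nM
Compound 2, `O=C(Nc1ccccc1I)N[C@H]1CC[C@H](Oc2ccc(F)cc2)CC1`: > 20000 nM

Both compounds were tested in a functional assay on CRL2813 cells (Homo sapiens) for cytotoxicity, read by sulforhodamine B assay, with a stated time of 5 days; a lower number here means a stronger inhibitor, a higher number a weaker inhibitor. Compound 2 gave only a limit, not a number, sitting at the limit of > 20000 nM in this assay, at which 1 of the 2 values shown sits. The step from compound 1 to compound 2 was an at least 8.6-fold higher number from compound 1 to compound 2 (0.93 log units; beyond the scatter), so compound 2 stands as the weaker of the two, though by an unknown margin.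

Compound 3, `Cc1ccccc1NC(=O)N[C@H]1CC[C@H](Oc2ccc(F)cc2)CC1`, differs from compound 2 by methyl in place of iodo on an aromatic carbon. Among the measured compounds shown here, no measured step exchanges one group for another at this same place, so the step from compound 1 to compound 2 bears on it only loosely: it shows that a 2-iodophenyl compound sits at the limit, but not what a 2-methylphenyl compound would do. With no direct guide, compound 3 is estimated at 15000 nM, within 3000 nM to 40000 nM, and the expected step is an at least 1.3-fold lower number from compound 2 to compound 3 (0.12 log units; that floor lies within the scatter).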

Compound 3, half-maximal inhibitory concentration: > 20000 nM
Compound 3 ended at the assay's limit (the forecaster's own chance of this, stated with the estimate: 45%); at least 1.3-fold (0.12 log units) between middle value and limit.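

In this assay, methyl in place of iodo still leaves the compound at the limit, so the weak result of compound 2 does not depend on iodo alone: the limit of > 20000 nM in this assay, at which 2 of the 3 values shown sit. Both values are limits, so the step between compound 2 and compound 3 cannot be read, and neither group can be ranked against the other. The 2-methylphenyl group also falls short of the 4-nitrophenyl group, with an at least 8.6-fold higher number from compound 1 to compound 3 (0.93 log units; beyond the scatter), so two different groups on the phenyl ring of the urea now give the same kind of drop from compound 1.

From the compounds shown here alone, it remains open whether compound 1 owes its measurable value to the nitro group itself or to where that group sits. Whether an amine or a carboxylic acid on this ring would bring a compound back below the limit is also unknown.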